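Changing the Aryl Group: From Compound 3 to Compound 4

The source may hold more compounds than are shown below. What is called first, only, known or untested is meant among the compounds shown, and "the series" means these compounds.

compound 1, `Cc1cc(C)cc(-c2nnc(COc3cnn(C(C)(C)C)c(=O)c3Cl)o2)c1`: > 300 ug/mL
compound 2, `CC(C)(C)n1ncc(OCc2nnc(-c3cccc(F)c3)o2)c(Cl)c1=O`: 7.1 ug/mL
compound 3, `CC(C)(C)n1ncc(OCc2nnc(-c3ccccc3F)o2)c(Cl)c1=O`: 16.8 ug/mL

Three compounds share a core and differ only in the aryl group on the five-membered ring. In a functional assay on the whole organism for inhibition, with Mythimna separata as the target, with a stated time of 5 days (a lower number here means that less compound is needed, a higher number that more compound is needed for the effect), compound 1 gives > 300 ug/mL. That value for compound 1 is a limit of the assay, not a number: the limit of > 300 ug/mL in this assay, at which 1 of the 3 values shown sits. Compound 2 gives 7.1 ug/mL and compound 3 gives 16.8 ug/mL. Compound 3 therefore holds the higher of the two numbers, with compound 2 nearest, a 2.4-fold higher number from compound 2 to compound 3 (0.37 log units; beyond the scatter).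

Compound 4, `Cc1cccc(-c2nnc(COc3cnn(C(C)(C)C)c(=O)c3Cl)o2)c1`, has not yet been measured; its change from compound 3 is 3-methylphenyl in place of 2-fluorophenyl on an aromatic carbon. For the measured compounds named here, the steps that bear on it are an at least 17-fold lower number from compound 1 to compound 3 (1.25 log units; beyond the scatter) and an at least 42-fold lower number from compound 1 to compound 2 (1.62 log units; beyond the scatter), both large, and a 2.4-fold higher number from compound 2 to compound 3 (0.37 log units; beyond the scatter), modest. Going by the values given here, compound 1, the only measured compound with a methyl-bearing aryl group, sits at the limit, and compound 4 keeps one of those methyls while losing the fluorine, so a higher number than for compound 3 is expected, a 2.7-fold higher number from compound 3 to compound 4 (0.43 log units; beyond the scatter). Compound 4 is estimated at 45 ug/mL, with a range from 12 ug/mL to 300 ug/mL.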

Compound 4, half-maximal effective concentration: 116 ug/mL
The estimate for compound 4 lay 2.6-fold (0.41 log units) below the measured number; the measured number falls inside the stated range.
By their numbers in this assay, from the lowest: compound 2; then compound 3; then compound 4. At a limit, above all of these: compound 1.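

In this assay, the new result shows that the choice between fluoro and methyl on the aryl group matters far more than the fluorine's place on it did: a 16-fold higher number from compound 2 to compound 4 (1.21 log units; beyond the scatter), a large step for a swap of that one group, and a 6.9-fold higher number from compound 3 to compound 4 (0.84 log units; beyond the scatter), a modest one. Taking one methyl away from the 3,5-dimethylphenyl group also brings a measurable number, an at least 2.5-fold lower number from compound 1 to compound 4 (0.41 log units; beyond the scatter), so a single methyl does not reach the limit. Compound 1 stands at a limit and not at a number, so that last step has only one bound: the limit of > 300 ug/mL in this assay, at which 1 of the 4 values shown sits.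

The compounds shown leave open whether a chlorine, a methoxy group or a trifluoromethyl group on the aryl group would fall with the fluoro compounds or with the methyl compounds. They also cannot tell what lies behind the gap between fluoro and methyl.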